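This account rests on a few compounds, and the source may have more. Where it says the series, first, only, none or still open, it means among the compounds named here.

Of the compounds shown here, two of a shared core have been measured in a functional assay for inhibition, with Homo sapiens as the target; a lower number here means a stronger inhibitor, a higher number a weaker inhibitor. Compound 1, `c1coc(-c2ccnc(Nc3ccc(-n4ccnc4)cc3)n2)c1`, gives 2200 nM in this assay. Compound 2, `CC(=O)N(C)c1ccc(Nc2nccc(-c3ccncc3)n2)cc1`, gives 500 nM in this assay, the lower of the two numbers, and the gap to compound 1 lies beyond the usual scatter. The next step leads to compound 3, `c1cc(-c2ccnc(Nc3ccc(-n4ccnc4)cc3)n2)ccn1`, which differs from compound 2 in one place: 1H-imidazol-1-yl in place of acetyl(methyl)amino on an aromatic carbon. Going by the values given here, no measured pair shows this change directly. Compound 3 carries the group found in compound 1, whose weaker number suggests some loss; a step of a 2.2-fold higher number from compound 2 to compound 3 (0.34 log units; beyond the scatter) is expected, towards a weaker inhibitor. Compound 3 is therefore estimated at 1100 nM, with a range from 350 nM to 3500 nM.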

Compound 3, half-maximal inhibitory concentration: 7600 nM
For compound 3 the middle estimate is 6.9-fold (0.84 log units) below the measured one, outside the stated range (above it).
By their numbers in this assay, from the lowest: compound 2; then compound 1; then compound 3.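

In this assay the change from acetyl(methyl)amino to 1H-imidazol-1-yl, on an aromatic carbon para to a large group, gives a 15-fold higher number from compound 2 to compound 3 (1.18 log units; beyond the scatter) and so is a large loss. The second ring also counts: pyridin-4-yl in place of furan-2-yl gives a 3.5-fold higher number from compound 1 to compound 3 (0.54 log units; beyond the scatter) with 1H-imidazol-1-yl held fixed, a modest loss. No supporting data explain either loss. Going by these compounds, whether acetyl(methyl)amino would keep its advantage alongside furan-2-yl remains open. So does how a simple amine or a carboxylic acid would fare at this position.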